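Methoxy added to the aryl ketone ring of compound 1

The source may report more compounds than this note shows. Statements on the series, on what has been measured and on what is new or still open speak of the compounds shown alone.

Three members of the series have been run in a functional assay on HeLa cells (Homo sapiens) for antiproliferative activity, read by sulforhodamine B assay, with a stated time of 48 h; a higher number here means a weaker inhibitor, a lower number a stronger inhibitor. Compound 1 `COc1cc(OC)c2sc(-c3ccc(N/C=C\C(=O)c4ccc(OC)c([N+](=O)[O-])c4)c(C)c3)nc2c1` gives 9390 nM. Compound 2 `COc1cc(OC)c2sc(-c3ccc(N/C=C\C(=O)c4ccc(OC)c(O)c4)cc3)nc2c1` gives 12100 nM in this assay, and compound 3 `COc1ccc(C(=O)/C=C\Nc2ccc(-c3nc4cc(OC)c(OC)c(OC)c4s3)cc2)cc1O` gives 14100 nM. Among the compounds with values here, the single change between the latter two is methoxy in place of hydrogen on an aromatic carbon, and it produced a 1.2-fold higher number from compound 2 to compound 3 (0.07 log units; within the scatter). Compound 1 stands nearest to compound 2 and furthest from compound 3, with both gaps within the scatter, so no ordering among the three is claimed. The difference between the core of compound 1 and that of compound 2 is not broken down here.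

Compound 4 `COc1cc(OC)c2sc(-c3ccc(N/C=C\C(=O)c4cc(OC)c(OC)c([N+](=O)[O-])c4)c(C)c3)nc2c1` has not been measured. It differs from compound 1 by methoxy in place of hydrogen on an aromatic carbon. Within the data shown here, this is the same kind of change as the one from compound 2 to compound 3, not the same change: in compound 3 the entering methoxy sits on a ring that is part of a fused or bridged system of two rings, ortho to two methoxy groups, meta to a fused ring and para to a fused ring, whereas in compound 4 it sits on a six-membered aromatic ring of carbon only, ortho to one methoxy group, meta to a large group and meta to a nitro group.

For compound 4 the expected step is a 1.1-fold higher number from compound 1 to compound 4 (0.05 log units; within the scatter), set beside a 1.2-fold higher number from compound 2 to compound 3 (0.07 log units; within the scatter); this rests only on that one earlier step, made at a different place, and on compound 1 at 9390 nM. Compound 4 is estimated at 10500 nM, with a likely range from 4000 nM to 28000 nM.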

Compound 4, half-maximal inhibitory concentration: 11400 nM
The estimate for compound 4 lay 1.1-fold (0.04 log units) below the measured number; the measured number falls inside the stated range.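

In this assay, methoxy in place of hydrogen on an aromatic carbon gives a 1.2-fold higher number from compound 1 to compound 4 (0.08 log units; within the scatter), so on the core of compound 1 this change does not move the number beyond the scatter. The earlier case on the other core agrees with it in size: the same change on two cores in this assay, a 1.2-fold higher number (0.07 log units; within the scatter) from compound 2 to compound 3 and a 1.2-fold higher number (0.08 log units; within the scatter) from compound 1 to compound 4, 1.0-fold (0.02 log units) apart, within the scatter of two such steps. This shows that in both available pairs the change stayed within the scatter, but it does not show a general, transferable effect of methoxy: neither step can be told from repeat measurement, the entering methoxy sits on a different ring in each pair, and two pairs cannot support a rule for the series.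

From the compounds shown here alone, it remains open whether any change on the aryl ketone ring can move the number beyond the scatter, for example an amine or a carboxylic acid in place of the nitro group. Compound 1 and compound 2 differ in more than one place, so the separate contributions of the nitro group, the hydroxyl group and the methyl group on the central aromatic ring also remain unresolved.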